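Anilide series: pyridinyl-amine to methoxybenzyl-amine step

The source may hold more compounds than are shown below. What is called first, only, known or untested is meant among the compounds shown, and "the series" means these compounds.

Measured compounds:
compound 1 `COc1ccc(CNc2nc(SCc3ccc(C(=O)Nc4ccccc4N)cc3)nn3cccc23)cc1`, 292 nM
compound 2 `Nc1cc(F)ccc1NC(=O)c1ccc(CSc2nc(Nc3cc[nH]n3)c3cccn3n2)cc1`, 731 nM
compound 3 `Cc1cccnc1Nc1nc(SCc2ccc(C(=O)Nc3ccc(F)cc3N)cc2)nn2cccc12`, 857 nM

In a functional assay on HCT-116 cells (Homo sapiens) for antiproliferative activity, read by luminescence, with a stated time of 72 h, tested at 1 uM (a higher number here means a weaker inhibitor, a lower number a stronger inhibitor), compound 3 gives the highest of the three numbers; compound 2 lies within the scatter of it, as the step of a 1.2-fold higher number from compound 2 to compound 3 (0.07 log units; within the scatter) shows, while compound 1 sits clearly lower. Compound 4 `COc1ccc(CNc2nc(SCc3ccc(C(=O)Nc4ccc(F)cc4N)cc3)nn3cccc23)cc1` has not yet been measured. The change from compound 3 is 4-methoxybenzyl in place of 3-methylpyridin-2-yl on a nitrogen on an aromatic ring. Within the data shown here, no measured step covers this exact exchange. Among the measured compounds shown here, the only near guide is compound 1, which carries the same 4-methoxybenzyl group on that nitrogen and differs from compound 4 only in the anilide ring; its value in this assay is well below that of compound 3. Compound 4 is therefore expected to move toward compound 1, with an estimated step of a 2.4-fold lower number from compound 3 to compound 4 (0.39 log units; beyond the scatter). The estimate for compound 4 is 350 nM, range 150 nM to 850 nM.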

Compound 4, half-maximal inhibitory concentration: 997 nM
Compound 4: middle estimate off by 2.8-fold (0.45 log units), on the low side, and the stated range ends below it.
By their numbers in this assay, from the lowest: compound 1; then compounds 2, 3 and 4 (each within the scatter of the next).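

In this assay, the group on this nitrogen does not separate the fluoro anilides: 4-methoxybenzyl in place of 3-methylpyridin-2-yl gives (a 1.2-fold higher number from compound 3 to compound 4 (0.07 log units; within the scatter)), and in place of 1H-pyrazol-3-yl gives (a 1.4-fold higher number from compound 2 to compound 4 (0.13 log units; within the scatter)). The lower number of compound 1 therefore does not come with 4-methoxybenzyl alone, since fluoro in place of hydrogen on an aromatic carbon gives (a 3.4-fold higher number from compound 1 to compound 4 (0.53 log units; beyond the scatter)). Nothing measured on these compounds bears on the reason. Still open, as far as these compounds go, is whether the same fluoro exchange gives a similar step with 3-methylpyridin-2-yl or 1H-pyrazol-3-yl on the nitrogen. Also open, from the compounds shown here alone, is whether an unsubstituted amino group at that place stays level with these compounds.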